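The source may report more compounds than this note shows. Statements on the series, on what has been measured and on what is new or still open speak of the compounds shown alone.

Compound 1 `CCc1nc(Cl)c2n1CCN([C@@H](C(=O)NC)c1ccccc1)[C@H]2CCc1cccc(C(F)(F)F)c1` gives 10 nM in a functional assay on CHO cells for antagonist activity at Orexin receptor type 2 (Homo sapiens), read by FLIPR and calcium flux; on this read-out lower numbers stand for stronger inhibition and higher numbers for weaker inhibition; compound 2 `CCc1nc(Cl)c2n1CCN([C@@H](C(=O)NC)c1ccccc1)[C@H]2CCc1ccc(C(F)(F)F)c(Cl)c1` gives 18 nM; compound 3 `CCc1nc(Cl)c2n1CCN([C@@H](C(=O)NC)c1ccccc1)[C@H]2CCc1ccc(C(F)(F)F)c(F)c1F` gives 14 nM.

Compound 2 carries the highest of the three numbers, yet its separation from compound 3, a 1.3-fold lower number from compound 2 to compound 3 (0.11 log units; within the scatter), and from compound 1, a 1.8-fold higher number from compound 1 to compound 2 (0.26 log units; within the scatter), both lie within the scatter. Compound 4 `CCc1nc(Cl)c2n1CCN([C@@H](C(=O)NC)c1ccccc1)[C@H]2CCc1cccc(C(F)(F)F)c1F` arises from compound 2 by 2-fluoro-3-(trifluoromethyl)phenyl in place of 3-chloro-4-(trifluoromethyl)phenyl on a saturated chain carbon, two bonds along the chain from a saturated ring carbon. Within the data shown here, the steps that bear on this change, a 1.8-fold higher number from compound 1 to compound 2 (0.26 log units; within the scatter) and a 1.4-fold higher number from compound 1 to compound 3 (0.15 log units; within the scatter), show that rearranging halogens and the trifluoromethyl group around this phenyl ring has so far moved this assay by no more than the scatter. Among the measured compounds shown here, no larger step is therefore expected from compound 2 to compound 4: a 1.5-fold lower number from compound 2 to compound 4 (0.18 log units; within the scatter). Compound 4 is estimated at 12 nM, between 5 nM and 30 nM.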

Compound 4, half-maximal inhibitory concentration: 9 nM
Compound 4: the middle estimate sits 1.3-fold (0.12 log units) above what was measured, within the range that was stated.
By their numbers in this assay, from the lowest: compounds 4, 1, 3 and 2 (each within the scatter of the next).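

In this assay, fluoro in place of hydrogen on an aromatic carbon of the phenyl group in compound 1 stays within the scatter (a 1.1-fold lower number from compound 1 to compound 4 (0.05 log units; within the scatter)), so this single added atom can now be read on its own. The two wider exchanges of the ring's substituents also stay within the scatter (a 2.0-fold lower number from compound 2 to compound 4 (0.30 log units; within the scatter)) and (a 1.6-fold lower number from compound 3 to compound 4 (0.19 log units; within the scatter)), so all four substituted phenyl groups at this place read alike.

The compounds shown leave open whether this holds for a phenyl group carrying an amine or a carboxylic acid, or for a longer chain in place of this one. What lies behind these small steps is not told by any measurement given here.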